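Series notes: isobutyl on the amine nitrogen

The source may hold more compounds than are shown below. What is called first, only, known or untested is meant among the compounds shown, and "the series" means these compounds.

Compound 1 `CCCC[Te]c1ccc(C(C)N)cc1` gives 12.1 ug/mL in a functional assay, read by spectrophotometry, with a stated time of 30 min (on this read-out lower numbers stand for stronger inhibition and higher numbers for weaker inhibition), the higher of the two numbers in hand. Compound 3 `CCCC[Te]c1ccc(/C(C)=N/N)cc1` gives 5.08 ug/mL, and the step of a 2.4-fold lower number from compound 1 to compound 3 (0.38 log units; beyond the scatter) lies beyond the scatter. Compound 2 `CCCC[Se]c1cccc(C(C)N)c1` is reported only as a limit, > 100 ug/mL, which is the limit of > 100 ug/mL in this assay, at which 1 of the 3 values shown sits. Compound 4 `CCCC[Te]c1ccc(C(C)NCC(C)C)cc1` differs from compound 1 by isobutyl in place of hydrogen on an amine nitrogen. Among the measured compounds shown here, no measured step alters the hydrogen on that amine nitrogen; the single step in hand, a 2.4-fold lower number from compound 1 to compound 3 (0.38 log units; beyond the scatter), reworks the whole amine-bearing group and was modest. Nothing here supports more than a small move in this assay, in either direction. Compound 4 is therefore expected near 10 ug/mL, with a range from 4 ug/mL to 30 ug/mL, an estimated step of a 1.2-fold lower number from compound 1 to compound 4 (0.08 log units; within the scatter).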

Compound 4, half-maximal inhibitory concentration: 12.5 ug/mL
Compound 4: the middle estimate sits 1.3-fold (0.10 log units) below what was measured, and the stated range covers the measured number.
By their numbers in this assay, from the lowest: compound 3; then compounds 1 and 4 (each within the scatter of the next). At a limit, above all of these: compound 2.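

In this assay the amine nitrogen takes isobutyl in place of hydrogen with a 1.0-fold higher number from compound 1 to compound 4 (0.01 log units; within the scatter), the first read on that hydrogen alone. The hydrogen on this nitrogen is therefore not required to hold the number, and this saturated branched chain is accepted there. No measured property bears on this result.

Still open, going by these compounds, is whether a methyl, a longer chain, a benzyl or an acetyl group on that nitrogen would also leave the number in place. On these data alone, it is equally open whether any group there can move it beyond the scatter.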